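The source may report more compounds than this note shows. Statements on the series, on what has been measured and on what is new or still open speak of the compounds shown alone.

Of the compounds shown here, three built on one shared core have been tested in an assay on HEK293 cells for agonist activity at transient receptor potential cation channel subfamily M member 8 (Homo sapiens), read by fluorescence and calcium flux, with a stated time of 15 min; a higher number here means that more compound is needed for the effect, a lower number that less compound is needed. Compound 1 `CCN(Cc1ccc(C)s1)C(=O)COc1ccc(C)cc1` gives 178 nM in this assay. Compound 2 `CCN(Cc1cc[nH]c1)C(=O)COc1ccc(C)cc1` gives 21800 nM. Compound 3 `CCN(Cc1ccsc1)C(=O)COc1ccc(C)cc1` gives 88 nM, the lowest of the three numbers, so it needs the least compound for the effect. The step of a 2.0-fold lower number from compound 1 to compound 3 (0.31 log units; beyond the scatter) is modest, whereas a 120-fold higher number from compound 1 to compound 2 (2.09 log units; beyond the scatter) and a 250-fold lower number from compound 2 to compound 3 (2.39 log units; beyond the scatter) are large, showing that the ring sitting on the saturated chain carbon bound to the amide-type nitrogen matters a great deal in this assay.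

Compound 4 `CCN(Cc1ccncc1)C(=O)COc1ccc(C)cc1` has not yet been measured. Relative to compound 3 it carries pyridin-4-yl in place of thiophen-3-yl on a saturated chain carbon bound to an amide-type nitrogen. The two large steps are the ones that bear on this change: they show that swapping the ring in this place for one built around a different hetero atom can move the number a long way. Among the compounds with values here, no measured compound carries a six-membered ring in this place, so the direction rests on one observation only: the thiophen-3-yl ring of compound 3 gave the lowest number, and every other ring tried gave a higher one. A step of a 17-fold higher number from compound 3 to compound 4 (1.23 log units; beyond the scatter) toward a higher number is therefore expected. Compound 4 is estimated to give 1500 nM in this assay, with a range from 200 nM to 12000 nM.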

Compound 4, half-maximal effective concentration: "not active" (no number reported)
Compound 4: no number reported, and the estimate cannot be compared.
By their numbers in this assay, from the lowest: compound 3; then compound 1; then compound 2.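

In this assay, within the data shown here, compound 4 is reported as "not active", with no number, so no step from compound 3 to compound 4 can be read. Nothing available explains this result. The compounds shown leave open whether any six-membered aromatic ring on a saturated chain carbon bound to an amide-type nitrogen can give a number here.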